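This account rests on a few compounds, and the source may have more. Where it says the series, first, only, none or still open, it means among the compounds named here.

Compound 1, `C[C@H](NCc1ccc(OCCCCCN2CCN(c3cccc4c3ccn4Cc3cccc(Cl)c3)CC2)cc1)C(N)=O`, in an assay on BTI cells for inhibition of Amine oxidase [flavin-containing] B (Homo sapiens), read by fluorescence, with stated times of 30 min and 1 h (on this read-out lower numbers stand for stronger inhibition and higher numbers for weaker inhibition), gives > 1000 nM, which is a limit of the assay and not a number. Compound 2, `C[C@H](NCc1ccc(OCCCCCN2CCN(c3cccc4c3ccn4S(=O)(=O)c3ccccc3)CC2)cc1)C(N)=O`, in this assay gives > 1000 nM, again a limit. The change between them is phenylsulfonyl in place of 3-chlorobenzyl on an aromatic nitrogen, and its step, a step that the two limits leave unreadable from compound 1 to compound 2, cannot be read as a size because both values sit at the limit of > 1000 nM in this assay, at which 2 of the 3 values shown sit. Going by the values given here, compound 3, `C#CCN(C)Cc1ccc(OCCCCN2CCN(c3cccc4c3ccn4Cc3cccc(Cl)c3)CC2)cc1`, is the one compound here with a true number: in this assay compound 3 gives 323 nM. How the core of compound 3 differs from the core of compound 1 is not broken down here. Compound 4, `C#CCN(C)Cc1ccc(OCCCCN2CCN(c3cccc4c3ccn4S(=O)(=O)c3ccccc3)CC2)cc1`, is not yet measured; it differs from compound 3 by phenylsulfonyl in place of 3-chlorobenzyl on an aromatic nitrogen, the same change as that from compound 1 to compound 2, at the same place. Since that earlier step gave no readable size, the expectation for compound 4 rests on compound 3 alone, with the step of a 1.5-fold higher number from compound 3 to compound 4 (0.19 log units; within the scatter) expected to be small and uncertain in direction. Compound 4 is therefore estimated at 500 nM, within 150 nM to 2000 nM.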

Compound 4, half-maximal inhibitory concentration: > 1000 nM
Compound 4: a limit, no number (the forecaster's own chance of this, stated with the estimate: 30%); middle value at least 2.0-fold (0.30 log units) away from the limit.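

In this assay, putting phenylsulfonyl in place of 3-chlorobenzyl on the aromatic nitrogen gives an at least 3.0-fold higher number from compound 3 to compound 4 (0.49 log units; beyond the scatter), so on the core of compound 3 this change weakens inhibition. The value of compound 4, > 1000 nM, is a limit of the assay and not a number. The same change on the core of compound 1 cannot be read as a step, so the series shows its effect on one core only and does not show that it carries from one core to another, because the values on that core sit at one ceiling: the limit of > 1000 nM in this assay, at which 3 of the 4 values shown sit.

Going by these compounds alone, only two groups appear on this nitrogen, and they differ in more than one feature, so it stays open whether a plain benzyl or a 3-chlorophenylsulfonyl group would behave like either of them. As far as these compounds go, it also stays open how a methyl group or a bare hydrogen at that place would compare on the core of compound 3.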